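A few compounds are considered here, and "the series" means these few. Any claim that something is new, unique, unknown or untested is made for them only; others in the source may bear on it.

Measured so far:
compound 1 `COc1cccc(N2C(=O)CS/C2=N\c2csc(-c3ccc(Cl)cc3)c2)c1` gives 24600 nM
compound 2 `CN(C)c1ccc(/C=C2\S/C(=N\c3nc(-c4ccc(Cl)cc4)cs3)NC2=O)cc1` gives 500 nM

In a functional assay on HT-29 cells (Homo sapiens) for cytotoxicity, read by MTT assay, with a stated time of 72 h (on this read-out lower numbers stand for stronger inhibition and higher numbers for weaker inhibition), compound 2 gives 500 nM, the lowest of the two numbers. Compound 1 gives 24600 nM, a higher number, and the gap between the two lies beyond the scatter. Among the compounds with values here, the two compounds differ at more than one place, so no single step between them is defined, and the pair says nothing about any one change on its own.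

Compound 3 `O=C1N/C(=N/c2nc(-c3ccc(Cl)cc3)cs2)S/C1=C\c1ccc(F)cc1` has not been measured in this assay. It differs from compound 2 by fluoro in place of dimethylamino on an aromatic carbon. Within the data shown here, no measured pair shows this change, so there is no directly comparable step to lean on. The expectation is for a moderate rise in the number, beyond the scatter, rather than a shift of the size seen between compound 1 and compound 2. Compound 3 is expected to give 2000 nM, within 500 nM to 8000 nM. The step from compound 2 to compound 3 is estimated at a 4.0-fold higher number from compound 2 to compound 3 (0.60 log units; beyond the scatter).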

Compound 3, half-maximal inhibitory concentration: 2900 nM
Compound 3: the middle estimate sits 1.5-fold (0.16 log units) below what was measured; the measured number falls inside the stated range.
By their numbers in this assay, from the lowest: compound 2; then compound 3; then compound 1.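

In this assay, within the data shown here, the change from 4-(dimethylamino)phenyl to 4-fluorophenyl gives the first step that can be read at a single place, a 5.8-fold higher number from compound 2 to compound 3 (0.76 log units; beyond the scatter), so the group on this six-membered aromatic ring, para to a large group, does bear on the number. The dimethylamino group is not needed for activity here, since compound 3 with fluoro still gives 2900 nM in this assay. No supporting data bear on why the number moves with this change.

One pair cannot show whether the step reflects the loss of dimethylamino or the arrival of fluoro. Going by these compounds, a methoxy group, a morpholine ring or plain hydrogen at the same place would separate the two, and whether the step holds on another core remains open.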